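Adding a methoxy to the trimethoxy-tetrahydroisoquinoline core

The source may hold more compounds than are shown below. What is called first, only, known or untested is meant among the compounds shown, and "the series" means these compounds.

Compounds measured in an assay on membranes from liver for displacement of a labelled ligand from Sigma intracellular receptor 2 (Rattus norvegicus), read by scintillation counting, with a stated time of 120 min (on this read-out higher numbers stand for weaker inhibition and lower numbers for stronger inhibition), so far:
compound 1 `COc1cc2c(c(OC)c1OC)CCN(CCCC(=O)c1c(C)c(OC)c(OC)c(OC)c1OC)C2` gives 41.8 nM;
compound 2 `COc1cc2c(cc1OC)CN(CCCCCC(=O)c1c(C)c(OC)c(OC)c(OC)c1OC)CC2` gives 0.38 nM;
compound 3 `COc1cc2c(c(OC)c1OC)CCN(CCCCCC(=O)c1c(C)c(OC)c(OC)c(OC)c1OC)C2` gives 19.7 nM.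

Compound 2 stands lowest of the three numbers in this assay. Its nearest neighbour is compound 3, reached by a 52-fold higher number from compound 2 to compound 3 (1.71 log units; beyond the scatter). Compound 1, which carries a shorter chain between the amine and the carbonyl than compound 3, lies furthest away. Compound 1 gives 41.8 nM, whereas compound 2 gives 0.38 nM.

Compound 4 `COc1cc2c(c(OC)c1OC)CN(CCCCCC(=O)c1c(C)c(OC)c(OC)c(OC)c1OC)CC2` has not yet been measured. It differs from compound 2 by methoxy in place of hydrogen on an aromatic carbon. Among the measured compounds shown here, the one measured step that bears on this is the step from compound 2 to compound 3, which is the same change, methoxy in place of hydrogen on an aromatic carbon, and gave a 52-fold higher number from compound 2 to compound 3 (1.71 log units; beyond the scatter), well beyond the scatter. A step of comparable size and in the same direction, towards a higher number, is therefore expected here. Compound 4 is expected at 15 nM in this assay, with a range of 4 nM to 60 nM, which corresponds to a 39-fold higher number from compound 2 to compound 4 (1.60 log units; beyond the scatter).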

Compound 4, inhibition constant: 12.6 nM
Estimate against measurement, compound 4: 1.2-fold (0.08 log units) above; the range from low to high includes it.
By their numbers in this assay, from the lowest: compound 2; then compounds 4 and 3 (each within the scatter of the next); then compound 1.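

In this assay the change of methoxy in place of hydrogen, here on an aromatic carbon ortho to a fused ring and ortho to a methoxy group, gives a 33-fold higher number from compound 2 to compound 4 (1.52 log units; beyond the scatter) and so matches the direction of a 52-fold higher number from compound 2 to compound 3 (1.71 log units; beyond the scatter) on a different aromatic carbon of the shared core. The rise in number is therefore not tied to a single aromatic carbon in this pair of compounds, and compound 3 and compound 4 stand within the scatter of each other, so the place of the added methoxy does not separate them in this assay. Nothing available on these compounds speaks to the reason for the size of this step.

Going by these compounds, whether a smaller group such as fluorine, or a hydroxyl, on this aromatic carbon would stay close to compound 2 at 0.38 nM remains open. Also open is how a longer chain between the amine and the carbonyl would behave with this added methoxy, since the only other chain length shown is the shorter one of compound 1 .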